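This account rests on a few compounds, and the source may have more. Where it says the series, first, only, none or still open, it means among the compounds named here.

Measured so far:
compound 1 `COc1ccccc1/C=C1\SC(=O)N(CCN)C1=O` — 29900 nM
compound 2 `CCCN1C(=O)/C(=C\c2ccncc2)SC1=S` — 10600 nM

In an assay on isolated protein for inhibition of Amine oxidase [flavin-containing] A (Homo sapiens), read by fluorescence (on this read-out higher numbers stand for weaker inhibition and lower numbers for stronger inhibition), compound 2 gives 10600 nM, the lowest of the two numbers in hand. Its nearest neighbour is compound 1, which in this assay gives 29900 nM, a gap that lies beyond the scatter. The two compounds differ in several places at once, so no single structural change can be tied to that gap.

Compound 3 `O=C1NC(=S)S/C1=C/c1ccncc1` is not yet measured. It differs from compound 2 in one place only: hydrogen in place of propyl on an amide-type nitrogen in a ring. Going by the values given here, no step between measured compounds isolates this change, so the expectation rests on compound 2 alone. The step is expected to be small, if anything a weakening, with the change from compound 2 to compound 3 estimated as a 1.9-fold higher number from compound 2 to compound 3 (0.28 log units; within the scatter). On that basis compound 3 is expected to give about 20000 nM in this assay, within a range of 6000 nM to 60000 nM.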

Compound 3, half-maximal inhibitory concentration: 21800 nM
Estimate against measurement, compound 3: 1.1-fold (0.04 log units) below; measured number inside the range.
By their numbers in this assay, from the lowest: compound 2; then compounds 3 and 1 (each within the scatter of the next).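

In this assay, going by these compounds alone, hydrogen in place of propyl on the amide-type nitrogen in the ring gives a 2.1-fold higher number from compound 2 to compound 3 (0.31 log units; beyond the scatter), the first step that isolates a single change. The propyl therefore contributes to the lower number of compound 2, but only modestly, and inhibition remains measurable with the nitrogen carrying hydrogen alone. Nothing in hand explains this step.

As far as these compounds go, two points remain open at this nitrogen: whether a longer chain such as butyl would lower the number further, and whether a chain ending in an amine or a carboxylic acid would move it at all. Also open, from the compounds shown here alone, is whether hydrogen in place of propyl would give a step of similar size on the core of compound 1.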